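The source may report more compounds than this note shows. Statements on the series, on what has been measured and on what is new or still open speak of the compounds shown alone.

The measured compounds:
- compound 1, `Nc1nc(N/N=C/c2ccc(OCc3ccc(F)cc3)cc2)nc2c1ncn2[C@@H]1O[C@H](CO)[C@@H](O)[C@H]1O`, gives 70 nM in an assay on CHO-K1 cells for displacement of a labelled ligand from adenosine receptor A1 (Homo sapiens), read by scintillation counting, with a stated time of 60 min; a lower number here means a stronger inhibitor, a higher number a weaker inhibitor
- compound 2, `CSCC/C=N/Nc1nc(N)c2ncn([C@@H]3O[C@H](CO)[C@@H](O)[C@H]3O)c2n1`, gives > 10000 nM in this assay
- compound 3, `CCCOc1ccc(/C=N/Nc2nc(N)c3ncn([C@@H]4O[C@H](CO)[C@@H](O)[C@H]4O)c3n2)cc1`, gives > 10000 nM in this assay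

Compound 3 stands at a limit of this assay: its result, > 10000 nM, is a threshold and not a number. Compound 2 likewise reports only a limit, > 10000 nM. This is the limit of > 10000 nM in this assay, at which 2 of the 3 values shown sit. Compound 1 alone gives a readable number, 70 nM.

Compound 4, `CN(C)c1ccc(/C=N/Nc2nc(N)c3ncn([C@@H]4O[C@H](CO)[C@@H](O)[C@H]4O)c3n2)cc1`, has not yet been measured. It differs from compound 3 by dimethylamino in place of propoxy on an aromatic carbon. Within the data shown here, two measured steps touch these structures. a step that the two limits leave unreadable from compound 2 to compound 3, so that pair gives no size. an at least 140-fold higher number from compound 1 to compound 3 (2.15 log units; beyond the scatter), a large loss, but it concerns a saturated chain carbon bound to the ring oxygen, not the aromatic carbon changed here, so it does not read directly onto the swap of propoxy for dimethylamino. Among the measured compounds shown here, no measured step therefore sets the size or direction of the step in this assay, and the plain expectation is that compound 4 again sits at the limit.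

Compound 4 is thus expected to show a number no higher from compound 3 to compound 4 (the limit leaves the size open). The estimate for compound 4 is 10000 nM, with a range from 2000 nM to 50000 nM, most likely reported again only as a limit.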

Compound 4, inhibition constant: > 10000 nM
Compound 4: a limit, no number; the forecaster's own chance of this, stated with the estimate: 65%; the middle value sits exactly at the limit.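

In this assay compound 4 also stops at a limit, so exchanging propoxy for dimethylamino on an aromatic carbon para to a large group still gives no readable number, and the limit now holds a further compound: the limit of > 10000 nM in this assay, at which 3 of the 4 values shown sit.

The steps from compound 2 and from compound 3 to compound 4 cannot be read, as limits stand at both ends, and they fix neither the size nor the direction of either change. The one readable step is an at least 140-fold higher number from compound 1 to compound 4 (2.15 log units; beyond the scatter), and it shows directly that dimethylamino in place of (4-fluorobenzyl)oxy on this aromatic carbon costs as much as the earlier change in the chain of the ether did, so among the compounds shown only the (4-fluorobenzyl)oxy group gives a readable number.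

What the compounds leave open is whether a benzyloxy group without the fluorine, or one carrying chlorine or methoxy on its outer ring, would keep a readable number at this carbon. As far as these compounds go, it also remains open how far propoxy and dimethylamino lie beyond the limit, and whether they differ at all.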